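A few compounds are considered here, and "the series" means these few. Any claim that something is new, unique, unknown or untested is made for them only; others in the source may bear on it.

Working notes on the series.

Compound 1 `N#CC1=C(N)OC(c2c[nH]c3ccccc23)=C(C#N)C1c1ccccc1F` is the starting point of this step. In a functional assay, tested at 200 ug/mL (on this read-out higher numbers stand for a stronger effect at the one concentration tested and lower numbers for a weaker effect), compound 1 gives "not active" (no number reported), so no number stands for it in this read-out, and the size of any step from it cannot be stated. The two measured aryl variants on the same saturated ring carbon are compound 2 `CN(C)c1ccc(C2C(C#N)=C(N)OC(c3c[nH]c4ccccc34)=C2C#N)cc1`, which in this assay gives 20.5%, and compound 3 `Cc1ccccc1C1C(C#N)=C(N)OC(c2c[nH]c3ccccc23)=C1C#N`, which in this assay gives 21.4%. Among the measured compounds shown here, the one measured step that bears on the present change is a number 0.9 percentage points higher from compound 2 to compound 3 (within the scatter), a swap of the aryl group on that saturated ring carbon that changes the read-out by a margin no larger than the scatter.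

Compound 4 `Cc1ccc(C2C(C#N)=C(N)OC(c3c[nH]c4ccccc34)=C2C#N)cc1` differs from compound 1 in one place: 4-methylphenyl in place of 2-fluorophenyl on a saturated ring carbon. With compound 1 reported without a number, no direction or size of step can be computed for this pair. What can be said is that both aryl variants measured so far gave a modest read-out of similar size, and the step between them stayed within the scatter, while compound 1 did not register. Compound 4 is therefore expected to fall in the modest range shown by compound 2 and compound 3 rather than at the level of compound 1, with a real chance of again returning no number. Compound 4 is estimated at 17% in this assay, within 2% to 32%.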

Compound 4, a percentage reported as activity, at one concentration (the size of the read-out at that concentration, not a potency): 6.2%
Beside the measured number, compound 4's estimate is 10.8 percentage points above it; the range from low to high includes it.
By their numbers in this assay, from the lowest: compound 4; then compounds 2 and 3 (each within the scatter of the next).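

The aryl group on the saturated ring carbon now shows a real effect in this assay: 4-methylphenyl in place of 2-methylphenyl gives a number 15.2 percentage points lower from compound 3 to compound 4 (beyond the scatter), whereas the earlier aryl swap stayed within the scatter. The second new step, with methyl in place of dimethylamino on an aromatic carbon, gives a number 14.3 percentage points lower from compound 2 to compound 4 (beyond the scatter), so among the three compounds with numbers the 4-methylphenyl variant alone stands apart, and compounds 2 and 3 remain level despite their different aryl groups. Among the compounds shown here, no step from compound 1 can be read, as compound 1 has no number, so the change from 2-fluorophenyl to 4-methylphenyl remains without a size or direction.

The data at hand offer no evidence that accounts for these steps. Still open, going by these compounds, is whether the low read-out belongs to the 4-methylphenyl group alone or extends to other groups on that aromatic carbon, such as an ethyl, a methoxy or a primary amine, and whether a 2-substituted aryl group other than 2-methylphenyl and 2-fluorophenyl, such as 2-chlorophenyl, gives a number in this read-out.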